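Trading One Small Azole for Another on the Amide Side

A few compounds are considered here, and "the series" means these few. Any claim that something is new, unique, unknown or untested is made for them only; others in the source may bear on it.

Compound 1, `Cc1cn(-c2cc(NC(=O)c3ccc(C)c(Nc4nc(-c5cccnc5)cs4)c3)cc(C(F)(F)F)c2)cn1`, gives 1830 nM in a functional assay on K562 cells (Homo sapiens) for antiproliferative activity; a higher number here means a weaker inhibitor, a lower number a stronger inhibitor.
Compound 2, `Cc1ccc(C(=O)Nc2cc(-n3ccnc3)cc(C(F)(F)F)c2)cc1Nc1nc(-c2cccnc2)cs1`, gives 2140 nM in this assay.
Compound 3, `Cc1ncn(-c2cc(NC(=O)c3ccc(C)c(Nc4nc(-c5cccnc5)cs4)c3)cc(C(F)(F)F)c2)n1`, gives 1630 nM in this assay.

These three compounds share one core and differ only in the small five-membered ring carried on the amide-side aromatic ring. The steps between them are all small: a 1.2-fold higher number from compound 1 to compound 2 (0.07 log units; within the scatter), a 1.1-fold lower number from compound 1 to compound 3 (0.05 log units; within the scatter) and a 1.3-fold lower number from compound 2 to compound 3 (0.12 log units; within the scatter). Compound 3 therefore sits within the usual scatter of both compound 1 and compound 2, and none of the three can be called the strongest or weakest.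

Compound 4, `Cc1ccc(C(=O)Nc2cc(-c3cnn(C)c3)cc(C(F)(F)F)c2)cc1Nc1nc(-c2cccnc2)cs1`, is the next member. It differs from compound 3 in one place: 1-methyl-1H-pyrazol-4-yl in place of 3-methyl-1H-1,2,4-triazol-1-yl on an aromatic carbon. The earlier steps shown here, each an exchange of the azole at this same position, all stayed within the scatter, so this further exchange is expected to do the same in this assay. The expected step is a 1.0-fold higher number from compound 3 to compound 4 (0.02 log units; within the scatter). Compound 4 is estimated at 1700 nM, with a likely range from 600 nM to 4800 nM.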

Compound 4, half-maximal inhibitory concentration: 5380 nM
The estimate for compound 4 lay 3.2-fold (0.50 log units) below the measured number, outside the stated range (above it).
By their numbers in this assay, from the lowest: compounds 3, 1 and 2 (each within the scatter of the next); then compound 4.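

This position is less forgiving than the earlier azole exchanges suggested: in this assay the change to 1-methyl-1H-pyrazol-4-yl gives a 3.3-fold higher number from compound 3 to compound 4 (0.52 log units; beyond the scatter) and a 2.5-fold higher number from compound 2 to compound 4 (0.40 log units; beyond the scatter) as well as a 2.9-fold higher number from compound 1 to compound 4 (0.47 log units; beyond the scatter) in the same direction, each modest but beyond the scatter. Compound 4 is also the only one of the four whose azole is joined to the aromatic ring through a ring carbon rather than a ring nitrogen, so the azoles here are not interchangeable simply by being small five-membered rings. Nothing measured here gives a reason for this difference.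

The compounds shown do not separate the joining atom from the placement of the methyl on the azole. They also leave open how this assay would respond to an amine or a carboxylic acid at this position.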